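The source may report more compounds than this note shows. Statements on the series, on what has been measured and on what is new or still open speak of the compounds shown alone.

Measured in an ADME assay on LLC-MK2 cells (Macaca mulatta) for cytotoxicity, read by spectrophotometry and crystal violet staining, with a stated time of 4 days; on this read-out higher numbers stand for lower toxicity in this test and lower numbers for higher toxicity in this test:
Compound 1 `CC(C)n1ncc2c(C(=O)N3CCc4cccnc43)cc(-c3cccs3)nc21`: 50000 nM
Compound 2 `CC(C)n1ncc2c(C(=O)Nc3ccc(F)cc3F)cc(-c3cccs3)nc21`: > 200000 nM (a limit)
Compound 3 `CC(C)n1ncc2c(C(=O)Nc3ccc(F)c(F)c3)cc(-c3cccs3)nc21`: > 200000 nM (a limit)

Compound 3 gives > 200000 nM, which is a limit of the assay and not a number. It stands at the limit of > 200000 nM in this assay, at which 2 of the 3 values shown sit.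

Compound 4 `CC(C)n1ncc2c(C(=O)Nc3ccc(F)cn3)cc(-c3cccs3)nc21` differs from compound 3 as follows: 5-fluoropyridin-2-yl in place of 3,4-difluorophenyl on an amide-type nitrogen. In words, this is 5-fluoropyridin-2-yl in place of 3,4-difluorophenyl on an amide-type nitrogen.

Going by the values given here, no measured step makes this exact change. The closest evidence comes from compound 1, which also has a six-membered aromatic ring with a hetero atom in its amide part, and there the data show an at least 4.0-fold higher number from compound 1 to compound 2 (0.60 log units; beyond the scatter) and an at least 4.0-fold higher number from compound 1 to compound 3 (0.60 log units; beyond the scatter). Those exchanges are much larger than the one at hand, so they offer only a weak hint of direction. The remaining comparison gives a step that the two limits leave unreadable from compound 2 to compound 3.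

A small move toward a lower number in this assay is therefore expected, estimated as an at least 1.3-fold lower number from compound 3 to compound 4 (0.12 log units; that floor lies within the scatter). For compound 4 the estimated value is 150000 nM, with an expected range from 60000 nM to 250000 nM.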

Compound 4, half-maximal cytotoxic concentration: > 200000 nM
Compound 4: only a limit was reported; the forecaster's own chance of this, stated with the estimate: 55%; at least 1.3-fold (0.12 log units) between middle value and limit.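

In this assay compound 4 gives > 200000 nM, which is a limit of the assay and not a number. The steps to compound 4 from compound 2 and compound 3 cannot be read, with limits at both ends, and the exchange of 3,4-difluorophenyl for 5-fluoropyridin-2-yl therefore has no measurable size here. The one readable step is an at least 4.0-fold higher number from compound 1 to compound 4 (0.60 log units; beyond the scatter), which shows that a six-membered aromatic ring with a hetero atom in the amide part does not on its own go with the lower number seen earlier, and the series now crowds at the top of the scale: the limit of > 200000 nM in this assay, at which 3 of the 4 values shown sit.

The compounds shown leave open how compound 2, compound 3 and compound 4 rank among themselves. They also leave open whether an amine or a carboxylic acid on the aromatic ring of the amide part would bring a measurable number within the range of the assay.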